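The compounds below may be only part of what the source reports. "The series", "measured", "known", "first", "only" and "open" are said of these compounds alone.

Measured compounds:
Compound 1 `COc1ccc(-c2c(I)c(=O)c3c(OC)cc(OC)cc3n2S(=O)(=O)c2ccc(OC)cc2)cc1` in a functional assay on SUP-B15 cells (Homo sapiens) for antiproliferative activity, with a stated time of 72 h; a lower number here means that less compound is needed, a higher number that more compound is needed for the effect: 12300 nM
Compound 2 `COC(=O)c1cc(=O)c2c(OC)cc(OC)cc2[nH]1` in this assay : 16100 nM
Compound 3 `COc1ccc(-c2cc(=O)c3c(OC)cc(OC)cc3n2S(=O)(=O)c2ccc(C)c([N+](=O)[O-])c2)cc1` in this assay : > 51700 nM, a limit of the assay and not a number

Compound 3 is the one of the three for which only a limit is known: its reading in this assay is > 51700 nM, the limit at which one of the three values sits (the limit of > 51700 nM in this assay, at which 1 of the 3 values shown sits). Compound 1 and compound 2 both return numbers, and those two numbers lie within the usual scatter of each other, so no order between them can be read. Compound 4 `COc1ccc(-c2cc(=O)c3c(OC)cc(OC)cc3n2S(=O)(=O)c2ccc(C)cc2)cc1` has not been measured. It differs from compound 3 in one place: hydrogen in place of nitro on an aromatic carbon. Among the compounds with values here, no step between two measured compounds is given here, so the size of this change cannot be read off from any measured pair. All three measured compounds sit in the weak range, and compound 3 only at the limit; the expectation is therefore a small step, if any, and one that can hardly go further upward. The step from compound 3 to compound 4 is estimated at an at least 1.4-fold lower number from compound 3 to compound 4 (0.16 log units; that floor lies within the scatter). For compound 4 the estimated value is 35000 nM, expected to lie between 12000 nM and 100000 nM.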

Compound 4, half-maximal effective concentration: > 44800 nM
Compound 4: a limit, no number; the forecaster's own chance of this, stated with the estimate: 40%; middle value at least 1.2-fold (0.10 log units) away from the limit.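

In this assay, compound 3 gives > 51700 nM, which is a limit and not a number. Compound 4 gives > 44800 nM, also a limit, so no step can be read between compound 3 and compound 4. The compounds shown leave open whether going from 4-methyl-3-nitrophenyl to 4-methylphenyl changes the antiproliferative activity at all.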